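Selenocyanate side-chain variation on a shared core: working notes

The source may hold more compounds than are shown below. What is called first, only, known or untested is meant among the compounds shown, and "the series" means these compounds.

Measured so far:
compound 1 `COc1ccc(N(C)c2nc(C)nc3ccccc23)cc1OCCC[Se]C#N` — 1040 nM
compound 2 `COc1ccc(N(C)c2nc(C)nc3ccccc23)cc1C(=O)NCC[Se]C#N` — 179 nM

Among the measured compounds shown here, in a functional assay on HepG2 cells (Homo sapiens) for inhibition, read by MTT assay, with a stated time of 48 h (on this read-out lower numbers stand for stronger inhibition and higher numbers for weaker inhibition), compound 2 holds the lowest of the two numbers, and the only measured step is a 5.8-fold lower number from compound 1 to compound 2 (0.76 log units; beyond the scatter), a modest gain that came with a change on an aromatic carbon. Compound 3 `COc1ccc(N(C)c2nc(C)nc3ccccc23)cc1C(=O)OCCCCC[Se]C#N` differs from compound 2 by a group of 9 heavy atoms (6 carbon, 1 nitrogen, 1 oxygen, 1 selenium; no ring) in place of a group of 6 heavy atoms (3 carbon, 2 nitrogen, 1 selenium; no ring), on a carbonyl carbon. For the measured compounds named here, no measured step covers a change on a carbonyl carbon, so the one step is only loosely relevant. The hydrogen-bond donor of compound 2 is lost and the chain lengthens, which gives no firm direction. A small weakening is expected for compound 3, estimated at 350 nM (range 120 nM to 1000 nM), a step of a 2.0-fold higher number from compound 2 to compound 3 (0.29 log units; within the scatter).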

Compound 3, half-maximal inhibitory concentration: 667 nM
The estimate for compound 3 lay 1.9-fold (0.28 log units) below the measured number, within the range that was stated.
By their numbers in this assay, from the lowest: compound 2; then compounds 3 and 1 (each within the scatter of the next).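

On the carbonyl carbon, this assay records a 3.7-fold higher number from compound 2 to compound 3 (0.57 log units; beyond the scatter), so a change at this place does move the number, and compound 2 keeps the lowest value of the series. This change removes the hydrogen-bond donor and lengthens the chain at once, and a single step cannot separate the two. Nothing available bears on the cause of the step.

Open, on these data alone, is whether an amide with the longer chain, or an ester with the shorter one, would read closer to compound 2 or to compound 3. Also open, as far as these compounds go, is how a carboxylic acid at this carbonyl carbon would read.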